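Adding a fused ring to a sulfonamide nitrogen

The source may hold more compounds than are shown below. What is called first, only, known or untested is meant among the compounds shown, and "the series" means these compounds.

Three compounds share one core and differ only in the group on the sulfonamide nitrogen. Compound 1 `CC(C)CN(c1ccc(F)cc1)S(=O)(=O)c1ccc2c(c1)C(O)CC(C1CCOCC1)O2` gives 3.39 in a physicochemical assay for lipophilicity, at pH 7.4; a lower number here means a more polar compound, a higher number a more lipophilic compound. Compound 2 `CCc1ccc(N(CC(C)C)S(=O)(=O)c2ccc3c(c2)C(O)CC(C2CCOCC2)O3)cc1` gives 4.12, and compound 3 `CC(C)CN(c1ccccc1F)S(=O)(=O)c1ccc2c(c1)C(O)CC(C1CCOCC1)O2` gives 3.39. Compound 3 thus sits level with compound 1 and together they are the lowest of the three numbers; compound 2 lies a number 0.73 log units lower from compound 2 to compound 3 (beyond the scatter).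

The next compound, compound 4 `CC(C)CN(C1CCc2ccc(F)cc21)S(=O)(=O)c1ccc2c(c1)C(O)CC(C1CCOCC1)O2`, is not yet measured. It differs from compound 3 in one place: 6-fluoro-2,3-dihydro-1H-inden-1-yl in place of 2-fluorophenyl on a sulfonamide nitrogen.

Within the data shown here, no measured step adds a second, non-aromatic ring, so the guide is indirect. The closest is a number 0.73 log units higher from compound 1 to compound 2 (beyond the scatter), where ethyl replaces fluoro and two carbons enter. Compound 4 gains three more carbons than compound 3, in a five-membered ring fused to the aromatic ring, while keeping the fluorine. A rise beyond the scatter is therefore expected, probably of similar or somewhat larger size than that ethyl step, and the step of a number 0.76 log units higher from compound 3 to compound 4 (beyond the scatter) is the expected outcome. Compound 4 is estimated at 4.15, in a range from 3.65 to 4.65.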

Compound 4, distribution coefficient: 3.94
The estimate for compound 4 lay 0.21 log units above the measured number, and the stated range covers the measured number.
By their numbers in this assay, from the lowest: compounds 1 and 3 (each within the scatter of the next); then compounds 4 and 2 (each within the scatter of the next).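

In this assay, the group on the sulfonamide nitrogen responds to a fused ring as well as to a change of substituent: 6-fluoro-2,3-dihydro-1H-inden-1-yl in place of 2-fluorophenyl gives a clear rise (a number 0.55 log units higher from compound 3 to compound 4 (beyond the scatter)), and in place of 4-fluorophenyl gives a rise of the same size (a number 0.55 log units higher from compound 1 to compound 4 (beyond the scatter)). Both groups that leave carry one fluorine, as does the group that enters, so these steps show the number moving beyond the scatter with the fluorine kept, whereas moving the fluorine around the phenyl ring did nothing visible (no change at the digits printed from compound 1 to compound 3 (within the scatter)). The fused-ring group and 4-ethylphenyl, one adding a five-membered non-aromatic ring and the other an ethyl chain, cannot be told apart in this assay (a number 0.18 log units lower from compound 2 to compound 4 (within the scatter)).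

Nothing shown gives a reason for any of these steps. As far as these compounds go, it remains open how this position would respond to a group such as an amine or a carboxylic acid on the ring, or to a longer chain in place of the ethyl.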